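This account rests on a few compounds, and the source may have more. Where it says the series, first, only, none or still open, it means among the compounds named here.

Of the compounds shown here, two have been measured in a physicochemical assay for solubility, at pH 7.4; on this read-out higher numbers stand for higher solubility and lower numbers for lower solubility. Compound 1 `Cc1ccc2c(NCc3ccc(NC(=O)c4ccc(F)cc4)cc3)nc(N3CCC3)nc2c1` gives 1 ug/mL in this assay. Compound 2 `CN(C)c1nc(NCc2ccc(NC(=O)c3ccc(F)cc3)cc2)c2ccc(I)cc2n1` gives > 100 ug/mL in this assay, which is a limit of the assay rather than a number, so compound 2 stands at the limit of > 100 ug/mL in this assay, at which 1 of the 2 values shown sits. Compound 3 `CC(O)c1ccc2c(NCc3ccc(NC(=O)c4ccc(F)cc4)cc3)nc(N(C)C)nc2c1` differs from compound 2 in one place: 1-hydroxyethyl in place of iodo on an aromatic carbon. For the measured compounds named here, with no measured step to draw on, the expected step that the limit leaves unreadable from compound 2 to compound 3 is none beyond the scatter. Compound 3 is therefore estimated at 120 ug/mL, within a range from 50 ug/mL to 300 ug/mL.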

Compound 3, solubility: 18 ug/mL
Compound 3: middle estimate off by 6.7-fold (0.82 log units), on the high side; measured number outside the range, below it.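

In this assay, 1-hydroxyethyl in place of iodo gives an at least 5.5-fold lower number from compound 2 to compound 3 (0.74 log units; beyond the scatter) on this aromatic carbon, so the group held at this position matters to the read-out. On these data alone, the true size of this step stays unknown, as compound 2 sits at a limit of the assay: the limit of > 100 ug/mL in this assay, at which 1 of the 3 values shown sits. The compounds shown do not separate the loss of iodo from the gain of 1-hydroxyethyl, and no cause for the step can be read from them. As far as these compounds go, how a small amine, a carboxylic acid or a plain ethyl chain would read at this position remains open.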